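Ortho substituent change on the aryl group, compound 4

This account rests on a few compounds, and the source may have more. Where it says the series, first, only, none or still open, it means among the compounds named here.

Measured compounds in a functional assay on HepG2 cells (Homo sapiens) for inhibition, read by MTT assay, with a stated time of 72 h; on this read-out higher numbers stand for weaker inhibition and lower numbers for stronger inhibition:
compound 1 `CC(C)n1ncc2c(C(=O)NCc3cn(-c4ccccc4)nn3)cccc21`: > 40000 nM
compound 2 `Cc1ccc(-n2cc(CNC(=O)c3cccc4c3cnn4C(C)C)nn2)c(C)c1`: > 40000 nM
compound 3 `Cc1ccccc1-n1cc(CNC(=O)c2cccc3c2cnn3C(C)C)nn1`: > 40000 nM

Compound 3 sits only at a limit of this assay, not at a number. The same holds for compound 1 and for compound 2, each reported only as a limit; all three stand at the limit of > 40000 nM in this assay, at which 3 of the 3 values shown sit. Compound 4 `CC(C)n1ncc2c(C(=O)NCc3cn(-c4ccccc4F)nn3)cccc21` differs from compound 3 by fluoro in place of methyl on an aromatic carbon. The steps that touch the same carbon, a step that the two limits leave unreadable from compound 1 to compound 3 and a step that the two limits leave unreadable from compound 2 to compound 3, both remain unreadable between two limits, so no size or direction can be drawn from them. Among the compounds with values here, nothing among the measured compounds suggests that compound 4 would move off the limit. Compound 4 is therefore estimated at 40000 nM, range 20000 nM to 80000 nM. The expected step of a number no higher from compound 3 to compound 4 (the limit leaves the size open) is none that the assay could resolve.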

Compound 4, half-maximal inhibitory concentration: > 40000 nM
Compound 4: no number, only a limit; the forecaster's own chance of this, stated with the estimate: 85%; the middle value lies on the limit itself.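

No new step can be read from compound 4 to compound 1, compound 2 or compound 3, since every comparison lies between two limits: the limit of > 40000 nM in this assay, at which 4 of the 4 values shown sit. The compounds shown leave open whether any substituent on this aryl group yields a number rather than a limit.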